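Swapping naphthalen-1-yl for 4-chlorophenyl: working notes

The source may report more compounds than this note shows. Statements on the series, on what has been measured and on what is new or still open speak of the compounds shown alone.

Of the compounds shown here, three have been read so far in a functional assay on RS4-11 cells (Homo sapiens) for inhibition, read by CCK-8 assay, with a stated time of 48 h; a lower number here means a stronger inhibitor, a higher number a weaker inhibitor. Compound 1 (`Cc1ccc(S(=O)(=O)Oc2ccccc2/C=C(\C#N)C(=O)Nc2nnc(C)s2)cc1`) reads > 20000 nM here, which is a limit of the assay and not a number. Compound 2 (`Cc1ccc(S(=O)(=O)Oc2cccc(/C=C(\C#N)C(=O)Nc3nnc(C)s3)c2)cc1`) reads > 20000 nM here, which is also a limit. This leaves the series with the limit of > 20000 nM in this assay, at which 2 of the 3 values shown sit, as its most common reading. Compound 3 (`COc1ccc(S(=O)(=O)Oc2ccccc2/C=C(\C#N)C(=O)Nc2nnc(Cc3cccc4ccccc34)s2)cc1`) gives 1360 nM in this assay and holds the only number shown, so it is the sole numerical anchor for what follows.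

Compound 4 (`COc1ccc(S(=O)(=O)Oc2ccccc2/C=C(\C#N)C(=O)Nc2nnc(Cc3ccc(Cl)cc3)s2)cc1`) carries 4-chlorophenyl in place of naphthalen-1-yl on a saturated chain carbon bound to an aromatic carbon. The same difference can be read as (naphthalen-1-yl)methyl to 4-chlorobenzyl. Within the data shown here, no measured pair isolates this change, so its size cannot be read from the data and the expectation is a cautious one. The estimated step is a 1.5-fold higher number from compound 3 to compound 4 (0.17 log units; within the scatter) in this assay and leans slightly towards weaker inhibition, with little or nothing expected beyond the scatter. For compound 4 the estimated value is 2000 nM with a wide expected range (600 nM to 8000 nM).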

Compound 4, half-maximal inhibitory concentration: 1250 nM
Estimate against measurement, compound 4: 1.6-fold (0.20 log units) above; the measured number falls inside the stated range.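

At this position, on a saturated chain carbon bound to an aromatic carbon, the change reads in this assay as a 1.1-fold lower number from compound 3 to compound 4 (0.04 log units; within the scatter), so 4-chlorophenyl can stand in place of naphthalen-1-yl without a step beyond the scatter. Among these compounds, this is the first single-place comparison, and it shows that one six-membered aromatic ring of carbon only, with 7 heavy atoms, holds the reading given by two such rings with 10 heavy atoms, so the second ring of naphthalen-1-yl is not required for this level of inhibition. With compound 4 the series has a second number, although limits still account for the rest of its readings: the limit of > 20000 nM in this assay, at which 2 of the 4 values shown sit.

Among the compounds shown here, the single step changes the ring count and introduces chlorine together, so it cannot assign any part of the result to either difference, and it gives no cause for the flat reading. Still open, as far as these compounds go, is whether the reading survives with a plain phenyl ring, with an amine or a carboxylic acid on that ring, or with a longer chain in place of the saturated chain carbon.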